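The compounds below may be only part of what the source reports. "The series", "measured", "known", "first", "only" and "open" are said of these compounds alone.

Of the compounds shown here, three have been measured in an assay on microsomes from liver for inhibition of 3-hydroxy-3-methylglutaryl-coenzyme A reductase (Rattus norvegicus); a higher number here means a weaker inhibitor, a lower number a stronger inhibitor. Compound 1, `CC[C@H](C)C(=O)O[C@H]1C[C@@H](C)C=C2C=C[C@H](C)[C@H](CC[C@@H]3C[C@@H](O)CC(=O)O3)[C@]21C`, gives 3 nM in this assay. Compound 2, `CC[C@H](C)C(=O)O[C@H]1C[C@H](O)C=C2C=C[C@H](C)[C@H](CCC(O)C[C@H](O)CC(=O)O)[C@]21C`, gives 5 nM in this assay. Compound 3, `O=C(O)C[C@H](O)C[C@H](O)CCn1c(C(F)(F)F)nc(-c2ccccc2)c1-c1ccc(F)cc1`, belongs to a different structural family and gives 31 nM in this assay. On these three numbers compound 3 stands highest: its number is beyond the usual scatter from that of compound 2 and further still from that of compound 1, so among the three measured compounds it is the weakest inhibitor.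

Compound 4, `Cc1cccc(-c2nc(C(F)(F)F)n(CC[C@@H](O)C[C@@H](O)CC(=O)O)c2-c2ccc(F)cc2)c1`, has not yet been measured. It differs from compound 3 in one place: methyl in place of hydrogen on an aromatic carbon. Put another way, a phenyl becomes a 3-methylphenyl, the methyl sitting meta to a large group. Going by the values given here, no measured pair shows this change, so these data give nothing to anchor its size or direction. With no measured guidance, the step from compound 3 to compound 4 in this assay is expected to be small, a 1.2-fold lower number from compound 3 to compound 4 (0.09 log units; within the scatter), and may well stay within the scatter. Compound 4 is accordingly estimated at 25 nM in this assay, with a range from 10 nM to 70 nM.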

Compound 4, half-maximal inhibitory concentration: 29 nM
Compound 4: the middle estimate sits 1.2-fold (0.06 log units) below what was measured, and the stated range covers the measured number.
By their numbers in this assay, from the lowest: compounds 1 and 2 (each within the scatter of the next); then compounds 4 and 3 (each within the scatter of the next).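

In this assay, turning the phenyl of compound 3 into the 3-methylphenyl of compound 4 gives a 1.1-fold lower number from compound 3 to compound 4 (0.03 log units; within the scatter), so on this measurement the two compounds cannot be told apart. Going by these compounds alone, this is the first measured step at this aromatic carbon, and it shows that a methyl can sit there, meta to a large group, while the number stays within the scatter of the one for compound 3. The data hold no separate measurement that could explain this result, so it stands only as an observation.

Going by these compounds, a single methyl at a single place says little about other groups, so it remains open whether an ethyl, a methoxy, a chlorine atom or an amine on this same carbon would also leave the number within the scatter. Within the data shown here, it also remains open whether a methyl on a different carbon of the same ring would behave as this one does, since only one place on the ring has been tested by a measured step.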